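Plasma stability notes: side-chain variation on compound 1

The compounds below may be only part of what the source reports. "The series", "measured", "known", "first", "only" and "open" are said of these compounds alone.

Measured so far in an ADME assay on a cell-free system (plasma, Homo sapiens) for metabolic stability, with Plasma (Rattus norvegicus) as the target, read by HPLC; a higher number here means that the compound lasts longer, a lower number that the compound disappears faster:
compound 1, `COc1cc(NC(C)CCCN2C(=O)CN(C(=O)[C@H](N)CCSC)C2(C)C)c2ncccc2c1`: > 3 h, a limit of the assay
compound 2, `COc1cc(NC(C)CCCN2C(=O)CNC2(C)C)c2ncccc2c1`: > 3 h, a limit of the assay
compound 3, `COc1cc(NC(C)CCCN2C(=O)CN(C(=O)[C@H](N)C(C)C)C2(C)C)c2ncccc2c1`: > 3 h, a limit of the assay

Compound 1 stands only at a limit in this assay, not at a number. The same holds for the two comparison compounds, as the limit of > 3 h in this assay, at which 3 of the 3 values shown sit, records. Consequently none of the measured steps can be read: a step that the two limits leave unreadable from compound 1 to compound 2, a step that the two limits leave unreadable from compound 1 to compound 3 and a step that the two limits leave unreadable from compound 2 to compound 3 are all unreadable in size and direction.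

Compound 4, `COc1cc(NC(C)CCCN2C(=O)CN(C(=O)[C@@H](C)N)C2(C)C)c2ncccc2c1`, differs from compound 1 as follows: hydrogen in place of (methylsulfanyl)methyl on a saturated chain carbon, two bonds along the chain from an amine nitrogen and a carbonyl carbon. For the measured compounds named here, the step that bears most directly on it is the one from compound 1 to compound 3, where the same carbon in the acyl side chain is altered; the step from compound 1 to compound 2, which removes the acyl group entirely, is the second point of reference. Both are unreadable, so no direction can be derived from them, and nothing in the present data places any acyl variant of this series at a measurable number.

Compound 4 is therefore expected to sit at the limit as well, with an estimated value of 4 h, range 2 h to 8 h. The step from compound 1 to compound 4 is estimated as a step that the limit leaves unreadable from compound 1 to compound 4, which is not expected to be readable either.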

Compound 4, half-life: > 3 h
Compound 4: only a limit was reported; the forecaster's own chance of this, stated with the estimate: 80%; the middle value does not contradict the limit.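

The steps linking compound 4 to compound 1, compound 2 and compound 3 cannot be read, as all four compounds stand at a limit, not a number: the limit of > 3 h in this assay, at which 4 of the 4 values shown sit.

The compounds shown leave open how long any of them lasts in this assay, and whether changing the acyl side chain on the amine nitrogen in the ring alters that at all.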